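The source may hold more compounds than are shown below. What is called first, only, known or untested is meant among the compounds shown, and "the series" means these compounds.

Three stilbene-type compounds have been tested in a functional assay on HT-29 cells (Homo sapiens) for inhibition, read by sulforhodamine B assay, with a stated time of 48 h (a higher number here means a weaker inhibitor, a lower number a stronger inhibitor), and a fourth awaits measurement. Compound 1, `CCNC(=O)Nc1ccc(/C=C\c2cc(C)cc(C)c2)cc1`, gives 11000 nM in this assay. Compound 2, `Cc1cc(C)cc(/C=C\c2ccc(N3CCNC3=O)cc2)c1`, differs from compound 1 in one place: 2-oxoimidazolidin-1-yl in place of (ethylcarbamoyl)amino on an aromatic carbon. That single exchange produced a 1300-fold lower number from compound 1 to compound 2 (3.12 log units; beyond the scatter), so compound 2 reaches 8.4 nM in this assay.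

Compound 3, `CCNC(=O)Nc1ccc(/C=C/c2cc(OC)c(OC)c(OC)c2)cc1`, carries the same (ethylcarbamoyl)amino group as compound 1 but on a different core; the difference between the two cores is not broken down here. In this assay compound 3 gives 12000 nM, a number that sits within the usual scatter of the value of compound 1, so the two cannot be told apart on potency.

Compound 4, `COc1cc(/C=C/c2ccc(N3CCNC3=O)cc2)cc(OC)c1OC`, is to compound 3 what compound 2 is to compound 1: 2-oxoimidazolidin-1-yl in place of (ethylcarbamoyl)amino on an aromatic carbon. The place is the same in both pairs, so this is the same change, seen twice among the compounds here. Among the measured compounds shown here, the only guide to its effect is the single measured pair, where the step was very large. Because compound 3 starts from 12000 nM, close to compound 1, a step of the same direction is expected, though with one example it may well turn out smaller: the estimated step is a 240-fold lower number from compound 3 to compound 4 (2.38 log units; beyond the scatter). Compound 4 is therefore expected to give about 50 nM in this assay, most likely between 8 nM and 400 nM.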

Compound 4, half-maximal inhibitory concentration: 370 nM
Beside the measured number, compound 4's estimate is 7.4-fold (0.87 log units) below it; the range from low to high includes it.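

In this assay, putting 2-oxoimidazolidin-1-yl in place of (ethylcarbamoyl)amino on the second core again gives a large step in the same direction, a 32-fold lower number from compound 3 to compound 4 (1.51 log units; beyond the scatter), so the direction of the change carries over from one core to the other. The size of the step does not carry over, as setting the two pairs side by side shows: the same change on two cores in this assay, a 1300-fold lower number (3.12 log units; beyond the scatter) from compound 1 to compound 2 and a 32-fold lower number (1.51 log units; beyond the scatter) from compound 3 to compound 4, 40-fold (1.61 log units) apart, beyond the scatter of two such steps. These two pairs do not show which feature of the cores sets the size of the step, since the cores differ in more than one place, and they give no rule for predicting the size on a third core.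

The compounds shown leave open whether closing the chain into a ring is what matters, or whether an open urea with a propyl chain, or a six-membered cyclic urea, would behave in the same way. They also leave open how the change would fare on a core carrying other groups, such as a halogen or a hydroxyl, in place of the methyl or methoxy groups seen here.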